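A few compounds are considered here, and "the series" means these few. Any claim that something is new, unique, unknown or untested is made for them only; others in the source may bear on it.

Measured so far:
compound 1 `CC(C)c1cc(-c2ccc(F)nc2F)nn(Cc2ccc(Cl)cc2)c1=O`: 56700 nM
compound 2 `N#Cc1ccc(Cn2nc(-c3ccc(F)nc3F)c3ccccc3c2=O)cc1`: > 100000 nM

For the measured compounds named here, in an ADME assay on HepG2 2.2.15 cells (Homo sapiens) for cytotoxicity, read by MTT assay, with a stated time of 8 days (a lower number here means that less compound is tolerated, a higher number that more compound is tolerated), compound 1 gives 56700 nM, the only plain number in the set. For compound 2 the reading in this assay is a limit of the assay and not a number, > 100000 nM. Compound 2 thus sits at the limit of > 100000 nM in this assay, at which 1 of the 2 values shown sits. Going by the values given here, no pair of measured compounds differs in one place, so no measured step is available.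

Compound 3 `COc1cc(-c2ccc(F)nc2F)nn(Cc2ccc(Cl)cc2)c1=O` is the next to be measured in this assay. Its change from compound 1 is methoxy in place of isopropyl on an aromatic carbon.

Among the compounds with values here, with no measured step to draw on, the change of methoxy in place of isopropyl on an aromatic carbon is expected to shift this assay by a small step at most, toward more compound tolerated or within the scatter. The estimate for compound 3 in this assay is 75000 nM, with a range from 30000 nM to 160000 nM, which is the expected step of a 1.3-fold higher number from compound 1 to compound 3 (0.12 log units; within the scatter).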

Compound 3, half-maximal cytotoxic concentration: 92200 nM
Estimate against measurement, compound 3: 1.2-fold (0.09 log units) below; measured number inside the range.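

For the compounds shown here, the first measured step, methoxy in place of isopropyl on an aromatic carbon opposite the ring nitrogen, gives a 1.6-fold higher number from compound 1 to compound 3 (0.21 log units; within the scatter) in this assay. At this position, then, replacing the all-carbon isopropyl with the oxygen-bearing methoxy does not separate compound 3 from compound 1 in this read-out. Going by these compounds alone, this single step shows only that this one exchange leaves the reading within the scatter, and it gives no trend and no cause.

Going by these compounds, whether an amine, a carboxylic acid or a longer alkoxy chain at the same carbon would move the number beyond the scatter stays open. Compound 2 remains a limit of the assay and not a number, so it offers no measured step here: the limit of > 100000 nM in this assay, at which 1 of the 3 values shown sits.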